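Removing the Bromo Group from Compound 1

The source may report more compounds than this note shows. Statements on the series, on what has been measured and on what is new or still open speak of the compounds shown alone.

In a functional assay on MIA PaCa-2 cells (Homo sapiens) for antiproliferative activity, read by sulforhodamine B assay, with a stated time of 48 h (a lower number here means a stronger inhibitor, a higher number a weaker inhibitor), compound 1 (`COc1cc(OC)c2sc(-c3ccc(N/C=C\C(=O)c4cc(OC)c(OC)c(OC)c4Br)c(C)c3)nc2c1`) gives 16000 nM. This lies within the scatter of compound 3 (`COc1ccc2nc(-c3ccc(N/C=C\C(=O)c4ccc(OC)c(O)c4)cc3)sc2c1`) at 21900 nM. Compound 2 (`COc1cc(OC)c2sc(-c3ccc(N/C=C\C(=O)c4ccc(OC)c([N+](=O)[O-])c4)cc3)nc2c1`) gives 2900 nM. It is a stronger inhibitor than compound 1, and the gap between the two lies beyond the scatter. Compound 4 (`COc1cc(OC)c2sc(-c3ccc(N/C=C\C(=O)c4cc(OC)c(OC)c(OC)c4)c(C)c3)nc2c1`) carries hydrogen in place of bromo on an aromatic carbon, a change counted as hydrogen in place of bromo on an aromatic carbon. Going by the values given here, no measured pair isolates this change, so the expectation is tentative. A moderate move toward a stronger inhibitor in this assay is expected, only slightly beyond the scatter, and the estimated size is a 2.7-fold lower number from compound 1 to compound 4 (0.43 log units; beyond the scatter). For compound 4 the estimated value is 6000 nM, with an expected range of 1500 nM to 20000 nM.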

Compound 4, half-maximal inhibitory concentration: 17000 nM
Beside the measured number, compound 4's estimate is 2.8-fold (0.45 log units) below it, within the range that was stated.
By their numbers in this assay, from the lowest: compound 2; then compounds 1, 4 and 3 (each within the scatter of the next).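

In this assay putting hydrogen in place of bromo on this aromatic carbon, ortho to a large group, gives a 1.1-fold higher number from compound 1 to compound 4 (0.03 log units; within the scatter) and so leaves the number within the scatter. This is the first pair shown that isolates a single change, and at this position it does not separate bromo from hydrogen. Nothing available explains this outcome.

On these data alone, whether an amine or a carboxylic acid on this carbon would also stay within the scatter remains open. So does whether this change would give the same result on another core.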